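The source may hold more compounds than are shown below. What is called first, only, known or untested is meant among the compounds shown, and "the series" means these compounds.

Three compounds have been measured in an ADME assay on the whole organism with Oryza sativa as the target, tested at 1 uM; on this read-out lower numbers stand for a stronger effect and higher numbers for a weaker effect at the one concentration tested:

compound 1, `Cc1cccc(NC(=O)N[C@H](C)c2ccccc2)c1`, gives 98%
compound 2, `CC(C)c1cccc(NC(=O)N[C@H](C)c2ccccc2)c1`, gives 61%
compound 3, `CC(C)c1cccc(NC(=O)N[C@@H](C)c2ccccc2)c1`, gives 84%

Compound 2 stands lowest of the three numbers, which on this read-out means the strongest effect of the three; compound 3 is nearest to it and compound 1 furthest. Compound 2 and compound 3 are built from the same atoms and bonds, and the step of a number 23 percentage points higher from compound 2 to compound 3 (beyond the scatter) rests on the fact that compounds 2 and 3 differ only in the configuration as drawn alone. The step of a number 37 percentage points lower from compound 1 to compound 2 (beyond the scatter) shows that replacing the group on an aromatic carbon can move the number a long way.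

The unmeasured compound 4, `CCOC(=O)c1cccc(NC(=O)N[C@H](C)c2ccccc2)c1`, differs from compound 2 by ethoxycarbonyl in place of isopropyl on an aromatic carbon. Going by the values given here, the only measured step that bears on this change is a number 37 percentage points lower from compound 1 to compound 2 (beyond the scatter), since it too replaced one group on an aromatic carbon. Ethoxycarbonyl is neither methyl nor isopropyl, so the direction is open, and a sizeable step either way would fit what has been seen. Given that methyl, in compound 1, gave 98% and isopropyl a much lower number, the expectation is that compound 4 moves part of the way back upward, with an estimated step of a number 19 percentage points higher from compound 2 to compound 4 (beyond the scatter). Compound 4 is therefore estimated at 80%, within 55% to 100%.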

Compound 4, a percentage reported as activity, at one concentration (the size of the read-out at that concentration, not a potency): 94%
Estimate against measurement, compound 4: 14 percentage points below; the range from low to high includes it.
By their numbers in this assay, from the lowest: compound 2; then compounds 3, 4 and 1 (each within the scatter of the next, the first and the last beyond it).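

In this assay, the gain seen with isopropyl does not carry over to every other group at this aromatic carbon: a number 33 percentage points higher from compound 2 to compound 4 (beyond the scatter). Ethoxycarbonyl brings 5 heavy atoms against the 3 of isopropyl, plus 2 hydrogen-bond acceptors, yet the comparison with the small methyl group gives a number 4 percentage points lower from compound 1 to compound 4 (within the scatter), so compounds 1 and 4 cannot be told apart on this read-out, and among these three compounds a larger group at this place does not simply go with a lower number, with compound 4 standing against any such trend. Going by these compounds alone, nothing measured so far explains why isopropyl differs from ethoxycarbonyl here.

On these data alone, it remains open whether the lower number belongs to isopropyl alone or would also appear with other groups at this place, such as tert-butyl, cyclopropyl or a carboxylic acid. As far as these compounds go, it is also open whether the opposite configuration at the saturated chain carbon would move the number of compound 4 in the way it separates compound 2 from compound 3.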